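This account rests on a few compounds, and the source may have more. Where it says the series, first, only, none or still open, it means among the compounds named here.

Measured compounds in an assay on HeLa cells for displacement of a labelled ligand from 5-hydroxytryptamine receptor 6 (Homo sapiens); on this read-out higher numbers stand for weaker inhibition and lower numbers for stronger inhibition:
- compound 1 `CSc1nc2ccccn2c(=N)c1S(=O)(=O)c1ccc(C(C)(C)C)cc1` gives 65 nM
- compound 2 `CSc1nc2ccccn2c(=N)c1S(=O)(=O)c1ccc(OC(F)(F)F)cc1` gives 420 nM
- compound 3 `C/N=c1/c(S(=O)(=O)c2ccccc2)c(SC)nc2ccccn12` gives 120 nM

Compound 3 sits second highest of the three numbers. Its number and that of compound 1 lie within the scatter of one another, so no order between them is claimed. Against compound 2, compound 3 shows the lower number, and that gap is beyond the scatter. Among the measured compounds shown here, the only step measured within one change is a 6.5-fold higher number from compound 1 to compound 2 (0.81 log units; beyond the scatter), which concerns the group on the aromatic carbon of the sulfonyl-bound ring, not the imine nitrogen.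

Compound 4 `CSc1nc2ccccn2/c(=N\C(C)=O)c1S(=O)(=O)c1ccccc1` differs from compound 3 by acetyl in place of methyl on a double-bonded nitrogen. For the measured compounds named here, no measured pair touches this nitrogen, so the measured step does not bear on the change directly; it only shows that a single replacement can move the number modestly. With nothing to indicate direction, the expected step is a 1.3-fold higher number from compound 3 to compound 4 (0.10 log units; within the scatter), not beyond the scatter. Compound 4 is therefore estimated at 150 nM in this assay, with a range from 50 nM to 500 nM.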

Compound 4, half-maximal inhibitory concentration: 83 nM
Beside the measured number, compound 4's estimate is 1.8-fold (0.26 log units) above it; the range from low to high includes it.
By their numbers in this assay, from the lowest: compounds 1, 4 and 3 (each within the scatter of the next); then compound 2.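

In this assay the double-bonded nitrogen now has a measured step of its own: acetyl in place of methyl gives a 1.4-fold lower number from compound 3 to compound 4 (0.16 log units; within the scatter) and stays within the scatter. On this nitrogen, therefore, a group of 3 heavy atoms with 1 hydrogen-bond acceptor reads the same as methyl with 1 heavy atom and none, whereas the step on the aromatic carbon from compound 1 to compound 2 lies beyond the scatter. Nothing shown explains why the read-out holds across this change.

Going by these compounds, it remains open whether acetyl on this nitrogen would read the same with tert-butyl or trifluoromethoxy on the aromatic carbon. Also open, on these data alone, is how far this tolerance extends, for example to a longer acyl chain, a benzoyl group, or an acyl group carrying an amine or a carboxylic acid.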